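The source may report more compounds than this note shows. Statements on the series, on what has been measured and on what is new or still open speak of the compounds shown alone.

Of the compounds shown here, three have been measured in a functional assay on the whole organism (strain albino) for inhibition, with Rattus norvegicus as the target, read by paw edema, with stated times of 30 min and 1 h, at a dose of 0.28 mmol/kg by the oral route; a lower number here means less inhibition, a higher number more inhibition at the dose given (going by the name of the read-out). Compound 1 `CCn1c(SCC(=O)Nc2ccc(/C(C)=N/O)cc2)nnc1-c1ccc(OC)c(OC)c1` gives 53%. Compound 2 `CCn1c(SCC(=O)Nc2ccc(/C(C)=N/O)cc2)nnc1-c1cc(OC)c(OC)c(OC)c1` gives 29%, and compound 3 `C=CCn1c(SCC(=O)Nc2ccc(/C(C)=N/O)cc2)nnc1-c1ccc(OC)c(OC)c1` gives 53%. From compound 2 to compound 1 the change is hydrogen in place of methoxy on an aromatic carbon, and the step is a number 24 percentage points higher from compound 2 to compound 1 (beyond the scatter). From compound 1 to compound 3 the step is no change at the digits printed from compound 1 to compound 3 (within the scatter), so compound 3 and compound 1 stand together at the top of the three numbers, with compound 2 beyond the scatter below them. The difference between the cores of compound 2 and compound 3 is not broken down here.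

Compound 4 `C=CCn1c(SCC(=O)Nc2ccc(/C(C)=N/O)cc2)nnc1-c1ccc(OC)cc1` is not yet measured. It differs from compound 3 by hydrogen in place of methoxy on an aromatic carbon. This is the same kind of change as that from compound 2 to compound 1, though the surroundings differ: in compound 2 the place is also meta to a methoxy group, which is not so in compound 3. The expected step for compound 4, a number 7 percentage points higher from compound 3 to compound 4 (within the scatter), rests on the earlier step of a number 24 percentage points higher from compound 2 to compound 1 (beyond the scatter). It is kept smaller than that step, as a single example is thin support. Compound 4 is expected to give 60%, between 42% and 76%.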

Compound 4, a percentage reported as inhibition, in the whole organism at one dose (the size of the read-out at that dose, not a potency): 54%
Beside the measured number, compound 4's estimate is 6 percentage points above it, within the range that was stated.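

In this assay, the change from 3,4-dimethoxyphenyl to 4-methoxyphenyl gives a number 1 percentage points higher from compound 3 to compound 4 (within the scatter), so the rise seen with the same replacement of methoxy by hydrogen on the other core does not carry over to this one: the same change on two cores in this assay, a number 24 percentage points higher (beyond the scatter) from compound 2 to compound 1 and a number 1 percentage points higher (within the scatter) from compound 3 to compound 4, 23 percentage points apart, beyond the scatter of two such steps

The result therefore argues against treating this replacement as a fixed increment across the series, and the effect of removing a methoxy group has to be read separately on each core. Among these compounds, it does not show why the two steps differ, as only two pairs are available, the cores differ in more than one place, and neither pair separates those differences.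

The compounds shown leave open how the read-out responds when the remaining methoxy group gives way to another group, such as a chlorine atom or an amine. Also open, on these data alone, is whether a longer chain on the ring nitrogen, or a carboxylic acid in place of the oxime, would alter the picture.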